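This account rests on a few compounds, and the source may have more. Where it says the series, first, only, none or still open, it means among the compounds named here.

Compound 1 `COc1cc(-c2nnc(SCC(=O)c3ccccc3)n2N)cc(OC)c1OC` carries a phenyl group directly on the carbonyl carbon of the side chain that hangs from the shared core. In a functional assay on HepG2 cells (Homo sapiens) for antiproliferative activity, read by MTT assay, with a stated time of 48 h (on this read-out higher numbers stand for weaker inhibition and lower numbers for stronger inhibition), compound 1 gives 7800 nM. Compound 2 `COc1cc(-c2nnc(SCC(=O)Nc3ccc(C)cc3)n2N)cc(OC)c1OC` replaces that phenyl with (4-methylphenyl)amino on the carbonyl carbon, turning the ketone into an amide. In this assay compound 2 gives > 100000 nM, which is a limit of the assay rather than a measured number. Compound 2 thus stands at the limit of > 100000 nM in this assay, at which 1 of the 2 values shown sits. The step of an at least 12-fold higher number from compound 1 to compound 2 (1.10 log units; beyond the scatter) is therefore a large loss of potency.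

Compound 3 `COc1cccc(NC(=O)CSc2nnc(-c3cc(OC)c(OC)c(OC)c3)n2N)c1` differs from compound 2 by 3-methoxyphenyl in place of 4-methylphenyl on an amide-type nitrogen. Among the compounds with values here, no measured pair exchanges one substituted aryl group for another on the amide nitrogen; the single measured step, from the ketone of compound 1 to the amide of compound 2, concerns the amide itself and not this exchange. With compound 2 already at the limit and nothing pointing either way, the expected step of a number no higher from compound 2 to compound 3 (the limit leaves the size open) is none beyond the scatter. Compound 3 is accordingly estimated at 100000 nM, within 30000 nM to 300000 nM, most likely again reported only as a limit.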

Compound 3, half-maximal inhibitory concentration: > 100000 nM
Compound 3 ended at the assay's limit; the forecaster's own chance of this, stated with the estimate: 70%; the middle value lies on the limit itself.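

The large loss seen with the first amide is not tied to its 4-methylphenyl group: with (3-methoxyphenyl)amino on the carbonyl carbon, the shift recurs as an at least 12-fold higher number from compound 1 to compound 3 (1.10 log units; beyond the scatter). Exchanging 4-methylphenyl for 3-methoxyphenyl on the amide-type nitrogen adds an oxygen and a hydrogen-bond acceptor, yet it brings no measurable recovery of activity in this assay, and the step between the two amides cannot be read, as both ends are limits of the assay and not numbers. Among these compounds, then, the two amides share the same ceiling, while only the ketone, compound 1, gives a real number: the limit of > 100000 nM in this assay, at which 2 of the 3 values shown sit.

The compounds shown leave open whether any amide can regain activity here, as both amides carry a substituted phenyl group on the nitrogen and neither group can be ranked against the other. An amide bearing a cyclohexyl group or a longer chain ending in an amine on that nitrogen, or a ketone with a 4-chlorophenyl group on the carbonyl carbon, would help show whether the amide link or the aryl group governs the result.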